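A few compounds are considered here, and "the series" means these few. Any claim that something is new, unique, unknown or untested is made for them only; others in the source may bear on it.

Measured compounds:
Compound 1 `CC(C)S(=O)(=O)N1CCc2nc(C#Cc3ccccc3)sc2C1`: > 10000 nM
Compound 2 `CC(C)S(=O)(=O)N1Cc2nc(C#Cc3ccccc3)sc2C1`: > 10000 nM
Compound 3 `O=S(=O)(C1CCCCC1)N1CCc2nc(C#Cc3ccccc3)sc2C1`: > 10000 nM

In an assay on HEK293 cells for positive allosteric modulation of metabotropic glutamate receptor 5 (Homo sapiens), read by FLIPR, with a stated time of 1 h (on this read-out lower numbers stand for an effect already at smaller amounts and higher numbers for an effect only at larger amounts of compound), compound 1 gives > 10000 nM, which is a limit of the assay and not a number. Compound 2 likewise gives only a limit, > 10000 nM, in this assay. Compound 3 also stops at a limit there, > 10000 nM. The change from compound 1 to compound 3 is cyclohexyl in place of isopropyl on a sulfonyl sulfur, and the step it made is a step that the two limits leave unreadable from compound 1 to compound 3; its size cannot be read because of the limit of > 10000 nM in this assay, at which 3 of the 3 values shown sit. How the core of compound 2 differs from that of compound 1 is not broken down here.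

Compound 4 `O=S(=O)(C1CCCCC1)N1Cc2nc(C#Cc3ccccc3)sc2C1` has not yet been measured in this assay. It differs from compound 2 by cyclohexyl in place of isopropyl on a sulfonyl sulfur, the same change as from compound 1 to compound 3, at a place described in the same words. Since that earlier step is unreadable, no direction can be taken from it; the expectation rests on compound 3 sitting at its limit > 10000 nM. The step this implies is expected to be a step that the limit leaves unreadable from compound 2 to compound 4. Compound 4 is therefore estimated at 20000 nM, most likely between 5000 nM and 100000 nM, and probably reported again only as a limit.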

Compound 4, half-maximal effective concentration: 150 nM
Estimate against measurement, compound 4: 130-fold (2.12 log units) above, and the stated range ends above it.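

In this assay cyclohexyl in place of isopropyl on a sulfonyl sulfur gives an at least 66-fold lower number from compound 2 to compound 4 (1.82 log units; beyond the scatter) and so, on the core of compound 2, the change turns a compound stopped at a limit into one with a measured value. The same change on the core of compound 1 leads to compound 3, and compound 3 gives > 10000 nM and this is a limit of the assay and not a number. The series therefore does not show whether the change carries over from one core to the other, nor that it fails to, because the step on the core of compound 1 cannot be read: the limit of > 10000 nM in this assay, at which 3 of the 4 values shown sit.

From the compounds shown here alone, it stays open how a cyclopentyl, a phenyl or a longer chain such as n-butyl on the sulfonyl sulfur would read on the core of compound 2. Going by these compounds, it also stays open whether any such group would bring the core of compound 1 to a measured value.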